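Swapping a Hydroxyphenyl for a Methylphenyl on the Shared Core

A few compounds are considered here, and "the series" means these few. Any claim that something is new, unique, unknown or untested is made for them only; others in the source may bear on it.

Compound 1 `O=C(/C=C/c1ccc2c(c1)B(O)OC2)c1ccc(Cl)c(Cl)c1`: > 10 ug/mL
Compound 2 `O=C(/C=C/c1ccc2c(c1)B(O)OC2)c1ccc(O)cc1`: > 10 ug/mL
Compound 3 `COc1ccccc1C(=O)/C=C/c1ccc2c(c1)B(O)OC2`: 6.35 ug/mL

In an ADME assay on L929 cells (Mus musculus) for cytotoxicity, read by resazurin assay, with a stated time of 72 h (on this read-out higher numbers stand for weaker inhibition and lower numbers for stronger inhibition), compound 1 reaches only a limit of the assay, not a number. Compound 2 likewise stops at a limit. Compound 2 therefore sits at the limit of > 10 ug/mL in this assay, at which 2 of the 3 values shown sit, and only compound 3 gives a true number. Going by the values given here, no step between measured compounds is available, so no measured effect of any change can be read off.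

Compound 4 `Cc1cccc(C(=O)/C=C/c2ccc3c(c2)B(O)OC3)c1` differs from compound 2 by 3-methylphenyl in place of 4-hydroxyphenyl on a carbonyl carbon. With the hydrogen-bond donor and acceptor gone, a modest move toward stronger inhibition beyond the scatter is expected, though a limit remains possible. Compound 4 is expected to give 8 ug/mL, within 4 ug/mL to 16 ug/mL. The expected step of an at least 1.2-fold lower number from compound 2 to compound 4 (0.09 log units; that floor lies within the scatter) is an estimate only.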

Compound 4, half-maximal inhibitory concentration: 8.56 ug/mL
The estimate for compound 4 lay 1.1-fold (0.03 log units) below the measured number; the measured number falls inside the stated range.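

Going by these compounds alone, putting 3-methylphenyl in place of 4-hydroxyphenyl on a carbonyl carbon gives an at least 1.1-fold lower number from compound 2 to compound 4 (0.06 log units; that floor lies within the scatter) in this assay and so provides the first step at this position. As far as these compounds go, that step is only a floor, and its true size stays unknown because compound 2 stops at a limit: (the limit of > 10 ug/mL in this assay, at which 2 of the 4 values shown sit).

From the compounds shown here alone, the change removes the hydroxyl and adds the methyl together, so the effect of each alone remains open. Also open, going by these compounds, is how a phenyl ring carrying an amine or a carboxylic acid at this place would read in this assay when compared with compound 4.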